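The source may hold more compounds than are shown below. What is called first, only, known or untested is meant among the compounds shown, and "the series" means these compounds.

Going by the values given here, compound 2 `COc1ccccc1C(=O)Nc1cccc(-c2oc3cc(-c4ccc(F)cc4)ccc3c(=O)c2O)c1` stands highest of the two numbers so far: in a functional assay on HeLa cells (Homo sapiens) for antiproliferative activity, read by CCK-8 assay, with a stated time of 72 h (a higher number here means a weaker inhibitor, a lower number a stronger inhibitor), compound 2 gives 14100 nM, while compound 1 `COc1ccc(C(=O)Nc2cccc(-c3oc4cc(-c5ccc(F)cc5)ccc4c(=O)c3O)c2)cc1` gives 4820 nM, the one measured step being a 2.9-fold higher number from compound 1 to compound 2 (0.47 log units; beyond the scatter). Compound 3 `O=C(Nc1cccc(-c2oc3cc(-c4ccc(F)cc4)ccc3c(=O)c2O)c1)c1ccc(C(F)(F)F)cc1` differs from compound 2 by 4-(trifluoromethyl)phenyl in place of 2-methoxyphenyl on a carbonyl carbon. Among the compounds with values here, no measured step involves a trifluoromethyl group, so only the resemblance of 4-(trifluoromethyl)phenyl to the 4-methoxyphenyl of compound 1 guides the expectation. Compound 3 is therefore expected near compound 1, with a step of about a 2.8-fold lower number from compound 2 to compound 3 (0.45 log units; beyond the scatter). The estimate for compound 3 is 5000 nM, within 1800 nM to 15000 nM.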

Compound 3, half-maximal inhibitory concentration: 17400 nM
For compound 3 the middle estimate is 3.5-fold (0.54 log units) below the measured one; the measured number lies above the stated range.
By their numbers in this assay, from the lowest: compound 1; then compounds 2 and 3 (each within the scatter of the next).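

In this assay, trifluoromethyl in place of methoxy on the same aromatic ring gives a 3.6-fold higher number from compound 1 to compound 3 (0.56 log units; beyond the scatter), so a group on that ring in the 4-(trifluoromethyl)phenyl arrangement does not match the result of 4-methoxyphenyl. The other comparison gives a 1.2-fold higher number from compound 2 to compound 3 (0.09 log units; within the scatter), so 4-(trifluoromethyl)phenyl and 2-methoxyphenyl cannot be told apart on this carbonyl carbon. Nothing available here explains either result. Still open, from the compounds shown here alone, is whether the lower number of compound 1 depends on the methoxy oxygen specifically, which a 4-ethoxyphenyl or 4-aminophenyl group on the same carbonyl carbon could test.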